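A few compounds are considered here, and "the series" means these few. Any claim that something is new, unique, unknown or untested is made for them only; others in the source may bear on it.

In a functional assay on CCRF-CEM cells (Homo sapiens) for cytotoxicity (on this read-out lower numbers stand for stronger inhibition and higher numbers for weaker inhibition), three dimeric lactones have been measured so far. Compound 1 `C=C1C(=O)O[C@H]2C[C@@H](C)C3=C(C[C@H]12)[C@@]1(C)C[C@@H]3C[C@@]12C(=O)O[C@@H]1C[C@@]3(C)[C@@H](O)C[C@@H](O)C(=C)[C@@H]3C[C@@H]12` gives 140 nM, the lowest number of the three. Compound 2 `C=C1C(=O)O[C@H]2CC(C)[C@@]34C[C@@H](C=C3C[C@H]12)[C@@]1(C4)C(=O)O[C@H]2CC(=C)[C@H]3CC[C@@](C)(O)[C@@H]3C[C@@H]21` gives 2030 nM, and compound 3 `C=C1C(=O)O[C@H]2C[C@H](C)[C@@]34C[C@@H](C[C@@]35C(=O)O[C@H]3CC(=C)[C@H]6CC[C@@](C)(O)[C@@H]6C[C@@H]35)C(C)=C4C[C@H]12` gives 2030 nM. Both of these lie well beyond the usual scatter from compound 1, on the weaker side, and they match each other.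

Compound 4 `C=C1C(=O)O[C@H]2C[C@H](C)C3=C(C[C@H]12)[C@@]1(C)C[C@H]3C[C@@]12C(=O)O[C@@H]1C[C@@]3(C)[C@@H](O)C[C@@H](O)C(=C)[C@@H]3C[C@@H]12` is a stereoisomer of compound 1: the two compounds have the same atoms and bonds and differ only in configuration as drawn: 2 of 12 stereo elements differ; a stereocentre at a saturated ring carbon is drawn R in compound 1 and S in compound 4; a stereocentre at a saturated ring carbon is drawn R in compound 1 and S in compound 4. Nothing leaves and nothing enters, since the two compounds have the same atoms and bonds. The change lies only in configuration as drawn, with two stereocentres at saturated ring carbons drawn R in compound 1 and S in compound 4.

Within the data shown here, the measured compounds include no pair that differs in one place, so the data offer no direct gauge of what such an inversion does in this assay. Compound 1 holds the lowest number, so a change in its configuration is expected to weaken inhibition moderately, though a step within the scatter cannot be excluded. The expected shift is a 2.9-fold higher number from compound 1 to compound 4 (0.46 log units; beyond the scatter), an estimate that carries wide uncertainty. For compound 4 the estimated value is 400 nM, with an expected range from 110 nM to 1800 nM.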

Compound 4, half-maximal inhibitory concentration: 140 nM
Estimate against measurement, compound 4: 2.9-fold (0.46 log units) above, within the range that was stated.
By their numbers in this assay, from the lowest: compounds 1 and 4 (each within the scatter of the next); then compounds 2 and 3 (each within the scatter of the next).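

In this assay, inverting the two stereocentres at saturated ring carbons gives no change at the digits printed from compound 1 to compound 4 (within the scatter). Among these compounds, this is the first pair that differs in one place, so it supplies the direct gauge that the earlier compounds lacked, and at these two stereocentres the drawn configuration, taken as a pair, leaves the cytotoxicity read-out within the scatter. The comparison is a clean one, with no group leaving or entering to blur the reading, and this holds for a single reason: the fact that compounds 1 and 4 differ only in the configuration as drawn

The compounds shown do not separate the two stereocentres, so it remains open whether inverting either one alone would also leave the number in place, or whether two opposing shifts happen to cancel in compound 4. They also leave open how the read-out would respond to a new group on the core of compound 1, such as an amine or a carboxylic acid, and whether the insensitivity to configuration seen here would persist in such a compound.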